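Replacing the Methoxy Group of Compound 2 With Hydrogen

The compounds below may be only part of what the source reports. "The series", "measured", "known", "first", "only" and "open" are said of these compounds alone.

Two measured compounds frame this step. Compound 1 `O=C(Nn1c(-c2cccc([N+](=O)[O-])c2)nc2c(-c3ccc(Cl)cc3)n[nH]c2c1=O)c1ccccc1` was tested in a functional assay on HT-29 cells (Homo sapiens) for inhibition, read by MTT assay, with a stated time of 2 days (a higher number here means a weaker inhibitor of growth, a lower number a stronger inhibitor of growth), where compound 1 gives 18500 nM. Compound 2 `COc1cccc(-c2nc3c(-c4ccc(Cl)cc4)n[nH]c3c(=O)n2NC(=O)c2ccccc2)c1` gives 20400 nM in this assay. On these two numbers compound 2 stands at the higher one, but only by a 1.1-fold higher number from compound 1 to compound 2 (0.04 log units; within the scatter), so the two compounds cannot be told apart on this evidence.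

Compound 3 `O=C(Nn1c(-c2ccccc2)nc2c(-c3ccc(Cl)cc3)n[nH]c2c1=O)c1ccccc1` has not yet been measured. It differs from compound 2 in one place: hydrogen in place of methoxy on an aromatic carbon. Going by the values given here, the only measured step that bears on this position is the one from nitro to methoxy, a 1.1-fold higher number from compound 1 to compound 2 (0.04 log units; within the scatter), which left the number essentially where it was. With two quite different groups at this aromatic carbon giving the same result, nothing in the data suggests that what sits there governs growth inhibition, so no step beyond the scatter is expected in this assay when the methoxy group gives way to hydrogen. Compound 3 is therefore expected to give 19000 nM, in the range 8000 nM to 45000 nM, an expected step of a 1.1-fold lower number from compound 2 to compound 3 (0.03 log units; within the scatter).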

Compound 3, concentration for 50% growth inhibition: 20600 nM
For compound 3 the middle estimate is 1.1-fold (0.04 log units) below the measured one; measured number inside the range.
By their numbers in this assay, from the lowest: compounds 1, 2 and 3 (each within the scatter of the next).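

Compound 3 adds what the earlier pair could not give: a reading with no substituent at all on this aromatic carbon, so the comparison is no longer only between one group and another. In this assay, taking the methoxy group away gives a 1.0-fold higher number from compound 2 to compound 3 (0.00 log units; within the scatter), and hydrogen set against nitro gives a 1.1-fold higher number from compound 1 to compound 3 (0.05 log units; within the scatter), so hydrogen, methoxy and nitro cannot be told apart here, and among these three compounds neither substituent on this ring shows any measurable contribution to growth inhibition beyond what the unsubstituted phenyl of compound 3 already gives. No information is available that would account for this result.

What the compounds shown leave open is whether this flat reading would hold for a basic amine, a carboxylic acid or a longer chain such as a butoxy group at the same carbon, since all three groups tested here are small or absent. They also leave open whether the other parts of the molecule, the benzamide and the 4-chlorophenyl group on the shared core, would respond any differently to change.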